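The source may report more compounds than this note shows. Statements on the series, on what has been measured and on what is new or still open speak of the compounds shown alone.

Going by the values given here, compound 1 `Cn1c(-c2ccccc2)nc2c(NC3CCCC3)ncnc21` is one of three compounds measured in an assay on CHO cells for displacement of a labelled ligand from adenosine receptor A1 (Homo sapiens), read by scintillation counting, with a stated time of 3 h; a lower number here means a stronger inhibitor, a higher number a weaker inhibitor. Compound 1 gives 2.8 nM, the lowest of the three numbers. Its nearest neighbour is compound 3 `CCn1c(-c2ccccc2)nc2c(NC3CCCC3)ncnc21`, which in this assay gives 3.9 nM; methyl in place of hydrogen on a saturated chain carbon bound to an aromatic nitrogen brings a 1.4-fold higher number from compound 1 to compound 3 (0.14 log units; within the scatter). Compound 2 `CCn1c(-c2ccccc2)nc2c(NC3CCCCC3)ncnc21` gives 10 nM in this assay, and cyclopentyl in place of cyclohexyl on a nitrogen on an aromatic ring brings a 2.6-fold lower number from compound 2 to compound 3 (0.41 log units; beyond the scatter). Compound 4 `COc1ccc(-c2nc3c(NC4CCCC4)ncnc3n2C)cc1` differs from compound 1 by methoxy in place of hydrogen on an aromatic carbon. Among the compounds with values here, neither measured step touches the phenyl group: one alters the chain on the aromatic nitrogen, the other the cyclopentyl or cyclohexyl on a nitrogen on an aromatic ring, so no step here bears directly on this change. With nothing to point either way, the expected step is a 1.1-fold higher number from compound 1 to compound 4 (0.03 log units; within the scatter) in this assay, nothing beyond the scatter. Compound 4 is therefore estimated at 3 nM, within a range from 1 nM to 10 nM.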

Compound 4, inhibition constant: 75 nM
Compound 4: the middle estimate sits 25-fold (1.40 log units) below what was measured, outside the stated range (above it).
By their numbers in this assay, from the lowest: compounds 1 and 3 (each within the scatter of the next); then compound 2; then compound 4.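

The phenyl group, which neither earlier step touched, proves far from indifferent in this assay: going from phenyl to 4-methoxyphenyl brings a 27-fold higher number from compound 1 to compound 4 (1.43 log units; beyond the scatter). This step is larger than either of the two seen at other places on the core, so the aromatic carbon para to a large group matters more to this number than the chain on the aromatic nitrogen or the choice of cyclopentyl or cyclohexyl. Nothing shown here accounts for the size of the step.

With only methoxy at this position, the compounds shown leave open whether the step belongs to methoxy itself or would also come with a smaller group such as fluorine or hydroxyl on the same carbon. They also leave open whether 4-methoxyphenyl would bring a similar step alongside the ethyl chain of compound 3.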